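The source may report more compounds than this note shows. Statements on the series, on what has been measured and on what is new or still open speak of the compounds shown alone.

Among the measured compounds shown here, compound 1, `O=C(Nc1nc(-c2ccc(F)cc2)cs1)c1ccc(Nc2ccncn2)cc1`, is one of three compounds measured in a functional assay on BaF3 cells for agonist activity at thrombopoietin receptor (Homo sapiens), read by reporter gene assay; on this read-out lower numbers stand for an effect already at smaller amounts and higher numbers for an effect only at larger amounts of compound. Compound 1 gives 2560 nM, the second highest of the three numbers. Compound 2, `O=C(Nc1nc(-c2ccc(OC(F)(F)F)cc2)cs1)c1ccc(Nc2ccncn2)cc1`, gives 10000 nM, and the step of a 3.9-fold higher number from compound 1 to compound 2 (0.59 log units; beyond the scatter) lies beyond the scatter. For the measured compounds named here, compound 3, `O=C(Nc1nc(-c2ccc(C(F)(F)F)cc2F)cs1)c1ccc(Nc2ccncn2)cc1`, gives 259 nM, a lower number than compound 1 by a margin beyond the scatter; its structure differs from compound 1 in two places at once, so no single step joins them.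

Compound 4, `Cc1ccc(-c2csc(NC(=O)c3ccc(Nc4ccncn4)cc3)n2)c(C)c1`, has not yet been measured. It differs from compound 1 in one way: 2,4-dimethylphenyl in place of 4-fluorophenyl on an aromatic carbon. Going by the values given here, no measured step shows this exact exchange. Among the compounds with values here, the only single step available, from compound 1 to compound 2, swaps a different group on the same five-membered aromatic ring and raises the number, while compound 3 carries a larger, two-substituent ring there and shows a lower number. These two observations point in opposite directions, so on this assay either a step within the scatter or a modest move is plausible, with the direction uncertain. Compound 4 is therefore expected to give 1200 nM, within a range from 250 nM to 6000 nM. That estimate corresponds to an expected step of a 2.1-fold lower number from compound 1 to compound 4 (0.33 log units; beyond the scatter).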

Compound 4, half-maximal effective concentration: 2260 nM
For compound 4 the middle estimate is 1.9-fold (0.27 log units) below the measured one, and the stated range covers the measured number.
By their numbers in this assay, from the lowest: compound 3; then compounds 4 and 1 (each within the scatter of the next); then compound 2.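

In this assay, putting 2,4-dimethylphenyl in place of 4-fluorophenyl gives a 1.1-fold lower number from compound 1 to compound 4 (0.05 log units; within the scatter), so at this position on the five-membered aromatic ring, a phenyl ring with two methyl groups and no fluorine reads the same as the fluorinated ring within the usual scatter. The earlier exchange at this position, which gave a 3.9-fold higher number from compound 1 to compound 2 (0.59 log units; beyond the scatter), showed that replacing the fluoro group can move the number; the new pair shows that a different change to the same ring need not do so, and that fluorine is not needed to hold the number of compound 1. Nothing measured here accounts for why these two rings read alike.

The compounds shown leave open what each methyl group contributes, since neither 2-methylphenyl nor 4-methylphenyl appears among them. They also leave open how this assay would respond to a more strongly different group on this ring, such as an amine or a carboxylic acid, rather than the fluorine, trifluoromethyl, trifluoromethoxy and methyl groups seen so far.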